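Hydroxyphenyl position swap on the shared core

The compounds below may be only part of what the source reports. "The series", "measured", "known", "first", "only" and "open" are said of these compounds alone.

Two compounds carry the shared core with a furan-2-yl group, a chlorophenyl group and a hydroxyphenyl group. Compound 1 `Oc1ccc(-c2cc(-c3ccco3)nc(-c3ccccc3Cl)c2)cc1` bears a 4-hydroxyphenyl group and a 2-chlorophenyl group; in a functional assay on DU-145 cells (Homo sapiens) for cytotoxicity, read by CCK-8 assay and cell counting, with a stated time of 2 days (a higher number here means a weaker inhibitor, a lower number a stronger inhibitor), compound 1 gives 5300 nM. Compound 2 `Oc1cccc(-c2cc(-c3ccc(Cl)cc3)nc(-c3ccco3)c2)c1` bears a 3-hydroxyphenyl group and a 4-chlorophenyl group; in this assay compound 2 gives 11400 nM. Of the two numbers, compound 2 stands highest, and its gap to compound 1 lies beyond the usual scatter. For the measured compounds named here, the two compounds differ in two places at once, so no single step between them is counted.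

Compound 3 `Oc1ccc(-c2cc(-c3ccc(Cl)cc3)nc(-c3ccco3)c2)cc1` is not yet measured. It differs from compound 2 in one place only: 4-hydroxyphenyl in place of 3-hydroxyphenyl on an aromatic carbon. Going by the values given here, compound 1, which also carries a 4-hydroxyphenyl group, gives the lower of the two known numbers, but its chlorophenyl group differs too, so that comparison carries limited weight. A modest move toward a lower number is expected, on the edge of the scatter. The step from compound 2 to compound 3 is estimated as a 1.8-fold lower number from compound 2 to compound 3 (0.24 log units; within the scatter). For compound 3 the estimate is 6500 nM, within 2500 nM to 16000 nM.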

Compound 3, half-maximal inhibitory concentration: 7280 nM
Estimate against measurement, compound 3: 1.1-fold (0.05 log units) below; the measured number falls inside the stated range.
By their numbers in this assay, from the lowest: compounds 1, 3 and 2 (each within the scatter of the next, the first and the last beyond it).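

In this assay, 4-hydroxyphenyl in place of 3-hydroxyphenyl, on the aromatic carbon opposite the ring nitrogen and with the 4-chlorophenyl group held fixed, gives a 1.6-fold lower number from compound 2 to compound 3 (0.19 log units; within the scatter) and so does not separate the two hydroxyphenyl groups at this position. With the 4-hydroxyphenyl group held fixed, 4-chlorophenyl in place of 2-chlorophenyl gives a 1.4-fold higher number from compound 1 to compound 3 (0.14 log units; within the scatter) in this assay, so neither single change on the shared core is resolved from the scatter, and the earlier two-place contrast cannot be assigned to either one. No supporting measurement bears on these steps, and the reading rests on the cell numbers alone.

The compounds shown leave open whether a group of another kind on this phenyl ring, such as an amine, a methoxy group or a carboxylic acid in place of the hydroxyl, would produce a step beyond the scatter. As far as these compounds go, the furan-2-yl group is also constant across all three compounds, so what a thiophene or a simple methyl group at that place would do in this assay remains unknown.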